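Methoxy to Fluoro on the Shared Core

This account rests on a few compounds, and the source may have more. Where it says the series, first, only, none or still open, it means among the compounds named here.

In a functional assay on DU-145 cells (Homo sapiens) for inhibition, read by trypan blue exclusion, with a stated time of 96 h (on this read-out higher numbers stand for weaker inhibition of growth and lower numbers for stronger inhibition of growth), compound 1 `COc1ccc(/C=C(\C(=O)c2ccc(Br)cc2)S(=O)(=O)c2ccc(Br)cc2)cc1` gives 25000 nM, level with compound 2 `COc1ccc(/C=C(\C(=O)c2ccc(Br)cc2)S(=O)(=O)Cc2ccc(Cl)cc2)cc1` at 25000 nM; together they hold the highest numbers of the three measured. Compound 3 `COc1ccc(/C=C(\C(=O)c2ccc(Cl)cc2)S(=O)(=O)c2ccc(Br)cc2)cc1` gives 10000 nM. The step of no change at the digits printed from compound 1 to compound 2 (within the scatter) lies within the scatter, while a 2.5-fold lower number from compound 1 to compound 3 (0.40 log units; beyond the scatter) is modest. Compound 4 `O=C(/C(=C\c1ccc(F)cc1)S(=O)(=O)c1ccc(Br)cc1)c1ccc(Br)cc1` differs from compound 1 by fluoro in place of methoxy on an aromatic carbon. Neither measured step touches this change: one replaces the group on a sulfonyl sulfur, the other is a halogen swap on an aromatic carbon, so nothing measured bears directly on it. It is therefore expected that this assay shows no step beyond the scatter, a 1.3-fold lower number from compound 1 to compound 4 (0.10 log units; within the scatter). Compound 4 is estimated at 20000 nM, with a range from 8000 nM to 50000 nM.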

Compound 4, concentration for 50% growth inhibition: 4000 nM
Estimate against measurement, compound 4: 5.0-fold (0.70 log units) above, outside the stated range (below it).
By their numbers in this assay, from the lowest: compound 4; then compound 3; then compounds 1 and 2 (each within the scatter of the next).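

In this assay, the change from 4-methoxyphenyl to 4-fluorophenyl gives a 6.3-fold lower number from compound 1 to compound 4 (0.80 log units; beyond the scatter). This shows that the group on this aromatic carbon, para to a large group, matters to the read-out, which compounds 1, 2 and 3 could not show, as all three carry methoxy there. Nothing shown gives a reason for this step.

Going by these compounds, it remains open how an amine or a carboxylic acid would behave at this position. On these data alone, it is also open whether the fluoro change would give a similar step on the cores of compound 2 or compound 3.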